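A few compounds are considered here, and "the series" means these few. Any claim that something is new, unique, unknown or untested is made for them only; others in the source may bear on it.

Compound 3, `CC#CCN(C)C1CCN(CCCc2c[nH]c3ccc(-n4cnnc4)cc23)CC1`, gives 81 nM in an assay on CHO cells for binding affinity to 5-hydroxytryptamine receptor 1B (Homo sapiens); a higher number here means a weaker inhibitor, a lower number a stronger inhibitor. Among the three measured compounds it holds the lowest number. Its nearest neighbour is compound 2, `NC(=O)OC[C@H](NC1CCN(CCCc2c[nH]c3ccc(-n4cnnc4)cc23)CC1)c1ccccc1`, which gives 120 nM, a gap within the scatter; the furthest is compound 1, `COC[C@H](NC1CCN(CCCc2c[nH]c3ccc(-n4cnnc4)cc23)CC1)c1ccccc1`, which gives 210 nM, and the step of a 2.6-fold lower number from compound 1 to compound 3 (0.41 log units; beyond the scatter) is modest but beyond the scatter.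

The next compound, compound 4, `CC(CO)(NC1CCN(CCCc2c[nH]c3ccc(-n4cnnc4)cc23)CC1)c1ccccc1`, differs from compound 3 in one place: (1-(hydroxymethyl)-1-phenylethyl)amino in place of (but-2-yn-1-yl)(methyl)amino on a saturated ring carbon. The new group resembles the side chains of compound 1 and compound 2, each carrying a phenyl-bearing carbon on the amine with a one-oxygen arm.

Among the measured compounds shown here, two measured steps bear on this change. The step of a 2.6-fold lower number from compound 1 to compound 3 (0.41 log units; beyond the scatter) shows that replacing such a phenyl-bearing amine with the (but-2-yn-1-yl)(methyl)amino group lowered the number modestly, so going back to a phenyl-bearing amine is expected to raise it. The step of a 1.8-fold lower number from compound 1 to compound 2 (0.24 log units; within the scatter) shows that changing the oxygen-bearing arm itself stayed within the scatter. Compound 4 is therefore expected to return toward the values of compound 1 and compound 2, with a step of a 2.2-fold higher number from compound 3 to compound 4 (0.35 log units; beyond the scatter) expected to be modest.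

Compound 4 is estimated at 180 nM, with a likely range from 70 nM to 450 nM.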

Compound 4, half-maximal inhibitory concentration: 98 nM
For compound 4 the middle estimate is 1.8-fold (0.26 log units) above the measured one; low and high end bracket the measured number.
By their numbers in this assay, from the lowest: compounds 3, 4, 2 and 1 (each within the scatter of the next, the first and the last beyond it).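

In this assay, the (1-(hydroxymethyl)-1-phenylethyl)amino group on the saturated ring carbon stands level with the much smaller (but-2-yn-1-yl)(methyl)amino group (a 1.2-fold higher number from compound 3 to compound 4 (0.08 log units; within the scatter)), so a phenyl-bearing amine at this position does not in itself bring a higher number. Among the phenyl-bearing side chains the picture is split: the 1-(hydroxymethyl)-1-phenylethyl group stands level with the 2-(carbamoyloxy)-1-phenylethyl group (a 1.2-fold lower number from compound 2 to compound 4 (0.09 log units; within the scatter)), whereas its step from the 2-methoxy-1-phenylethyl group goes beyond the scatter (a 2.1-fold lower number from compound 1 to compound 4 (0.33 log units; beyond the scatter)). No measurement in hand accounts for these differences.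

The step from compound 1 to compound 4 swaps the methoxy end for a free hydroxyl and also adds a methyl on the phenyl-bearing carbon, so the compounds shown leave open which of the two changes carries it. They also leave open how an aminomethyl or a carboxylic acid arm in place of the hydroxymethyl would read in this assay.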